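A few compounds are considered here, and "the series" means these few. Any claim that something is new, unique, unknown or untested is made for them only; others in the source may bear on it.

The study reports values in an ADME assay on L1210/0 cells (Mus musculus) for cytotoxicity, with a stated time of 48 h (a lower number here means a stronger inhibitor, a higher number a weaker inhibitor), for three compounds:

Compound 1, `O=C(/C=C/c1cc(=O)[nH]c(=O)n1COCCO)c1ccccc1`, gives 43300 nM.
Compound 2, `Cc1ccc(C(=O)/C=C/c2cc(=O)[nH]c(=O)n2COCCO)cc1`, gives 27900 nM.
Compound 3, `Cc1cn(C[C@@H]2C[C@H](CO)c3ccccc32)c(=O)[nH]c1=O`, gives only a limit, > 200000 nM.

Compound 4, `O=c1ccn(C[C@@H]2C[C@H](CO)c3ccccc32)c(=O)[nH]1`, has not yet been measured in this assay. It is related to compound 3 by one change, (hydrogen in place of methyl on an aromatic carbon). The same kind of change links the two measured compounds 2 and 1, (hydrogen in place of methyl on an aromatic carbon), though the surroundings differ: in compound 3 the methyl sits on a six-membered aromatic ring with 2 nitrogen, ortho to a group of 1 heavy atom, two atoms from the ring nitrogen, meta to a large group and para to a group of 1 heavy atom, whereas in compound 2 it sits on a six-membered aromatic ring of carbon only, para to a large group. How the core of compound 3 differs from the core of compound 2 is not broken down here. The measured step is a 1.6-fold higher number from compound 2 to compound 1 (0.19 log units; within the scatter).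

For compound 3 the assay reports only a limit, which is the limit of > 200000 nM in this assay, at which 1 of the 3 values shown sits. On that basis the step from compound 3 to compound 4 is expected to be small, a step that the limit leaves unreadable from compound 3 to compound 4, in line with the measured step between compound 2 and compound 1. Compound 4 is therefore estimated at 250000 nM in this assay, within a range from 100000 nM to 600000 nM, and it is quite likely that the assay will again report only a limit for compound 4.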

Compound 4, half-maximal inhibitory concentration: > 200000 nM
Compound 4: a limit, no number; the forecaster's own chance of this, stated with the estimate: 75%; the middle value is on the limit's open side.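

In this assay, among the compounds shown here, compound 4 gives > 200000 nM, a limit and not a number, and compound 3 carries the same limit, so no step between the two can be read: the limit of > 200000 nM in this assay, at which 2 of the 4 values shown sit.

The compounds shown leave open how far compound 3 and compound 4 lie past that limit, and so whether hydrogen in place of methyl changes the read-out on this core at all.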